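Swapping the Ring-Nitrogen Substituent of Compound 2

The compounds below may be only part of what the source reports. "The series", "measured", "known", "first", "only" and "open" are said of these compounds alone.

Measured compounds:
compound 1, `N#Cc1ccccc1CN1CCc2c(sc(NC(=O)c3ccccc3Cl)c2C(N)=O)C1`, 10400 nM in a functional assay on HL-60 cells (Homo sapiens) for antiproliferative activity, with a stated time of 24 h; on this read-out higher numbers stand for weaker inhibition and lower numbers for stronger inhibition
compound 2, `NC(=O)c1c(NC(=O)c2ccccc2Cl)sc2c1CCN(C(=O)Nc1ccccc1Cl)C2`, 12500 nM in this assay

Compound 2 holds the highest of the two numbers in this assay, and its nearest neighbour is compound 1 at a distance of a 1.2-fold higher number from compound 1 to compound 2 (0.08 log units; within the scatter), a gap that lies within the scatter. The step from compound 1 to compound 2 replaced 2-cyanobenzyl with (2-chlorophenyl)carbamoyl on an amine nitrogen in a ring.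

Compound 3 `NC(=O)c1c(NC(=O)c2ccccc2Cl)sc2c1CCN(C(=S)Nc1ccccc1F)C2` has not been measured. It differs from compound 2 in a group of 10 heavy atoms (7 carbon, 1 nitrogen, 1 fluorine, 1 sulfur; one six-membered aromatic ring of carbon only) in place of a group of 10 heavy atoms (7 carbon, 1 nitrogen, 1 oxygen, 1 chlorine; one six-membered aromatic ring of carbon only), on an amine nitrogen in a ring, the place being the same amine nitrogen in a ring of the shared core. Among the compounds with values here, no measured step bears directly on this exchange: the only step available, from compound 1 to compound 2, concerned a different pair of groups on that nitrogen and was itself within the scatter. The expectation for compound 3 is therefore a step of a 1.0-fold lower number from compound 2 to compound 3 (0.02 log units; within the scatter), nothing beyond the scatter in either direction. Compound 3 is expected to give 12000 nM in this assay, with a range from 4500 nM to 32000 nM.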

Compound 3, half-maximal inhibitory concentration: 4970 nM
For compound 3 the middle estimate is 2.4-fold (0.38 log units) above the measured one; the range from low to high includes it.
By their numbers in this assay, from the lowest: compound 3; then compounds 1 and 2 (each within the scatter of the next).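

Within the data shown here, at the amine nitrogen in a ring, the exchange gave the first change in this assay to lie beyond the scatter, with a 2.5-fold lower number from compound 2 to compound 3 (0.40 log units; beyond the scatter) even though the group that entered matches (2-chlorophenyl)carbamoyl in its counts of heavy atoms, hydrogen-bond donors and hydrogen-bond acceptors, and in its aromatic ring. The same group also separates compound 3 from the 2-cyanobenzyl compound, with a 2.1-fold lower number from compound 1 to compound 3 (0.32 log units; beyond the scatter) and both steps pointing the same way, so this position can register a modest change even though 2-cyanobenzyl and (2-chlorophenyl)carbamoyl could not be told apart. No information on hand accounts for this shift.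

The step from compound 2 to compound 3 exchanges oxygen for sulfur and chlorine for fluorine at once, so the compounds shown cannot assign the change to either atom; a carbamoyl group with a fluorine-bearing phenyl ring, or a thiocarbamoyl group with the 2-chlorophenyl ring, would carry only one of the two exchanges. From the compounds shown here alone, whether a smaller group on this nitrogen, such as acetyl or a plain methyl, would fit the same trend also remains open.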